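Removing the Ring Methyl from Compound 2

The compounds below may be only part of what the source reports. "The series", "measured", "known", "first", "only" and "open" are said of these compounds alone.

Measured so far:
Compound 1, `CC1=CSC(O)(c2ccc([N+](=O)[O-])cc2)c2noc(=O)n21`: in a functional assay on A2780 cells (Homo sapiens) for antiproliferative activity, read by MTT assay, with a stated time of 3 days (on this read-out higher numbers stand for weaker inhibition and lower numbers for stronger inhibition), compound 1 gives > 100000 nM, which is a limit of the assay and not a number.
Compound 2, `CC1=CSC(O)(c2ccccc2)c2noc(=O)n21`: in this assay compound 2 gives > 100000 nM, again a limit.
Compound 3, `CC1=CSC(O)(c2cccc(Cl)c2)c2noc(=O)n21`: in this assay compound 3 gives > 100000 nM, again a limit.

Going by the values given here, compound 2 therefore stands at the same place as everything measured here: all three values sit at the limit of > 100000 nM in this assay, at which 3 of the 3 values shown sit, so no compound can be ranked against another. The two measured steps, a step that the two limits leave unreadable from compound 1 to compound 2 and a step that the two limits leave unreadable from compound 2 to compound 3, change a group on the phenyl ring, but because every value rests at the limit of > 100000 nM in this assay, at which 3 of the 3 values shown sit, their size cannot be read.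

Compound 4, `O=c1onc2n1C=CSC2(O)c1ccccc1`, differs from compound 2 elsewhere: hydrogen in place of methyl on a double-bonded ring carbon. Among the compounds with values here, no measured step touches this ring position, so the phenyl-ring steps only show that the shared core stayed at the limit through two changes. Compound 4 is expected to give 150000 nM, with a range from 50000 nM to 500000 nM. For compound 4 the expected step is a step that the limit leaves unreadable from compound 2 to compound 4, most likely reported as a limit once more.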

Compound 4, half-maximal inhibitory concentration: > 100000 nM
Compound 4 was reported as a limit; the forecaster's own chance of this, stated with the estimate: 85%; the middle value lies beyond the limit too.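

No size can be read for the change from compound 2 to compound 4, because both compounds rest at a limit of the assay and not at a number: the limit of > 100000 nM in this assay, at which 4 of the 4 values shown sit. The compounds shown leave open whether, in this assay, any change to the shared core gives a measurable value.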